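The source may hold more compounds than are shown below. What is called first, only, known or untested is meant among the compounds shown, and "the series" means these compounds.

Two compounds with the same shared core open the series. In an assay on Sf9 cells for inhibition of protein deacetylase HDAC6 (Homo sapiens), read by fluorescence, with a stated time of 40 min, tested at 100 nM (a lower number here means less inhibition, a higher number more inhibition at the concentration tested (going by the name of the read-out)), compound 1 `O=C(NO)c1ccc(NCc2nc(-c3ccc(Br)cc3)nn2-c2ccccc2)cc1` gives 54.7%, and compound 2 `Cc1ccccc1-n1nc(-c2ccccc2)nc1CNc1ccc(C(=O)NO)cc1` gives 57.1%. Compound 3 `O=C(O)c1ccc(NCc2nc(-c3ccccc3)nn2-c2ccccc2)cc1`, which carries a carboxy group on its phenyl instead, gives -0.4% in this assay, the lowest of the three numbers: compound 1 sits nearest and compound 2 furthest, both higher by more than the usual scatter. Compound 4 `NC(=O)c1ccc(NCc2nc(-c3ccccc3)nn2-c2ccccc2)cc1` differs from compound 3 in one place: amino in place of hydroxy on a carbonyl carbon. For the measured compounds named here, no measured pair here shows what exchanging carboxy for carbamoyl does, so the expectation leans on compound 3 alone. The step is expected to stay within the scatter, a number 5.4 percentage points higher from compound 3 to compound 4 (within the scatter). Compound 4 is accordingly estimated at 5%, within -10% to 25%.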

Compound 4, a percentage reported as inhibition, at one concentration (the size of the read-out at that concentration, not a potency): -4.4%
Estimate against measurement, compound 4: 9.4 percentage points above; low and high end bracket the measured number.
By their numbers in this assay, from the lowest: compounds 4 and 3 (each within the scatter of the next); then compounds 1 and 2 (each within the scatter of the next).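

In this assay, the exchange of hydroxy for amino on this carbonyl carbon is a step of a number 4 percentage points lower from compound 3 to compound 4 (within the scatter), so carboxy and carbamoyl cannot be told apart at this place. Compound 4, at -4.4%, shows no measurable inhibition at the concentration tested, and neither does the carboxy-bearing compound 3, at -0.4%. Nothing available explains this result. Going by these compounds, whether a methyl ester on the same carbonyl carbon would give a different reading remains open.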